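Short-chain anilides: halogen pattern change from compound 2 to compound 4

The compounds below may be only part of what the source reports. "The series", "measured", "known", "first", "only" and "open" are said of these compounds alone.

The series shares one core and varies the anilide end. Among the compounds with values here, in an assay on isolated protein (Mus musculus) for inhibition of IL15-IL15 receptor (Homo sapiens), read by resazurin assay, with stated times of 30 min and 2.5 days (on this read-out lower numbers stand for stronger inhibition and higher numbers for weaker inhibition), compound 1 `COc1ccc(NC(=O)CCCCCCCSc2nnc(Cc3nn(C)c(=O)c4ccccc34)n2C)cc1` gives 3900 nM and compound 3 `CCCOc1ccc(NC(=O)CCCCCCCSc2nnc(Cc3nn(C)c(=O)c4ccccc34)n2C)cc1` gives 1600 nM; the one defined step, a 2.4-fold lower number from compound 1 to compound 3 (0.39 log units; beyond the scatter), concerns the alkoxy substituent on the long-chain members only. Compound 2 `Cn1c(Cc2nn(C)c(=O)c3ccccc23)nnc1SCC(=O)Nc1ccc(I)cc1`, the short-chain member, is recorded in this assay as "not active" (no number reported), so it has no number to rank against the others.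

Compound 4 `Cn1c(Cc2nn(C)c(=O)c3ccccc23)nnc1SCC(=O)Nc1ccc(Br)cc1Br` differs from compound 2 only at the anilide ring: 2,4-dibromophenyl in place of 4-iodophenyl on an amide-type nitrogen. Within the data shown here, no measured step bears on this change directly; the step from compound 1 to compound 3 sits on a different chain and a different substituent, so it gives no guide here. With compound 2 at "not active" (no number reported), the expectation for compound 4 in this assay is weak inhibition, and it may likewise end up reported without a number. Compound 4 is estimated at 25000 nM, with a range of 5000 nM to 100000 nM.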

Compound 4, half-maximal inhibitory concentration: > 30000 nM
Compound 4 gave a limit, no number; the forecaster's own chance of this, stated with the estimate: 55%; at least 1.2-fold (0.07 log units) between middle value and limit.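

In this assay compound 4 gives > 30000 nM, a limit and not a number. Compound 2 has no number either, so no step can be read between compound 2 and compound 4. The compounds shown leave open whether 2,4-dibromophenyl and 4-iodophenyl differ in inhibition at all.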